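A Chloro Group Added to Compound 2

A few compounds are considered here, and "the series" means these few. Any claim that something is new, unique, unknown or untested is made for them only; others in the source may bear on it.

In a functional assay on HeLa cells (Homo sapiens) for cytotoxicity, read by sulforhodamine B assay, with a stated time of 48 h (a lower number here means a stronger inhibitor, a higher number a weaker inhibitor), compound 2 (`O=C(c1cccnc1)c1ccccc1O`) gives 33000 nM as the lowest of three numbers, and the other two lie beyond the scatter from it. Compound 1 (`C=CCOc1ccc(F)cc1C(=O)c1cccnc1`) gives 93000 nM and compound 3 (`C=CCOc1c(Cl)cccc1C(=O)c1cccnc1`) gives 100000 nM in the same read-out. Compound 4 (`O=C(c1cccnc1)c1cc(Cl)ccc1O`) departs from compound 2 by a single change (chloro in place of hydrogen on an aromatic carbon) that puts chloro in place of hydrogen on an aromatic carbon, para to a hydroxy group. Within the data shown here, no measured pair shows this change on its own, so the expectation is loose. The expected step (a 1.4-fold lower number from compound 2 to compound 4 (0.16 log units; within the scatter)) leans toward a lower number in this assay but is not expected to pass beyond the scatter. Compound 4 is expected at 23000 nM with a range of 9000 nM to 60000 nM as its estimate.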

Compound 4, half-maximal inhibitory concentration: 24000 nM
The estimate for compound 4 lay 1.0-fold (0.02 log units) below the measured number, and the stated range covers the measured number.
By their numbers in this assay, from the lowest: compounds 4 and 2 (each within the scatter of the next); then compounds 1 and 3 (each within the scatter of the next).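

Among these compounds, this is the first single-place comparison in the set: chloro in place of hydrogen on an aromatic carbon, para to a hydroxy group, gives a 1.4-fold lower number from compound 2 to compound 4 (0.14 log units; within the scatter) in this assay. The position therefore accepts a chloro group with no shift beyond the scatter, so the change neither clearly gains nor clearly loses activity here. No supporting measurement bears on the reason for this result. On these data alone, whether an amine or a carboxylic acid at this same position would also stay within the scatter remains open.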